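A few compounds are considered here, and "the series" means these few. Any claim that something is new, unique, unknown or untested is made for them only; others in the source may bear on it.

Compound 1 `CN1CCN(C(=O)/C=C/c2ccncc2-c2ccc3ccccc3c2)CC1`: > 10000 nM
Compound 2 `COC1CN(C(=O)/C=C/c2ccncc2-c2ccc3ccccc3c2)C1`: > 10000 nM
Compound 3 `O=C(/C=C/c1ccncc1-c1ccc2ccccc2c1)N1CCOCC1`: 8410 nM

Among the compounds with values here, in a functional assay on A549 cells (Homo sapiens) for inhibition, read by sulforhodamine B assay, with a stated time of 72 h (a higher number here means a weaker inhibitor of growth, a lower number a stronger inhibitor of growth), compound 3 gives the only actual number, 8410 nM. Compound 1 sits at a limit of the assay, > 10000 nM. Compound 2 sits at the same limit, > 10000 nM.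

Compound 4 `O=C(/C=C/c1ccncc1-c1ccc2ccccc2c1)NC1CC1` carries cyclopropylamino in place of morpholin-4-yl on a carbonyl carbon.

Earlier changes at this carbonyl carbon are an at least 1.1-fold lower number from compound 1 to compound 3 (0.07 log units; that floor lies within the scatter) and an at least 1.1-fold lower number from compound 2 to compound 3 (0.07 log units; that floor lies within the scatter), while a step that the two limits leave unreadable from compound 1 to compound 2 cannot be read. With only these small floors to go on, no step beyond the scatter is expected in this assay. The estimated step is a 1.0-fold higher number from compound 3 to compound 4 (0.00 log units; within the scatter). For compound 4 the expected value is 8500 nM, with an estimated range of 3500 nM to 15000 nM.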

Compound 4, concentration for 50% growth inhibition: 5840 nM
The estimate for compound 4 lay 1.5-fold (0.16 log units) above the measured number; the measured number falls inside the stated range.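

In this assay, cyclopropylamino brings a hydrogen-bond donor to this carbonyl carbon in place of morpholin-4-yl, and the result is a 1.4-fold lower number from compound 3 to compound 4 (0.16 log units; within the scatter). The donor-bearing group thus gives no step beyond the scatter at this position. Against the other two groups the comparison yields only floors, an at least 1.7-fold lower number from compound 2 to compound 4 (0.23 log units; that floor lies within the scatter) and an at least 1.7-fold lower number from compound 1 to compound 4 (0.23 log units; that floor lies within the scatter), and both rest on a limit: the limit of > 10000 nM in this assay, at which 2 of the 4 values shown sit.

From the compounds shown here alone, whether a longer chain on this nitrogen, such as n-butylamino, or a carboxylic acid at this carbonyl carbon would give a step beyond the scatter stays open. So does the true size of both floors.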